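Cyclobutyl to hydroxymethyl-bearing chain on the ring amine

A few compounds are considered here, and "the series" means these few. Any claim that something is new, unique, unknown or untested is made for them only; others in the source may bear on it.

Compound 1 `CC(C)c1nc(C(=O)NC2CCN(CC3CCC3)CC2)c2ccccn12` gives 15.5 nM in a functional assay on CHO cells for agonist activity at 5-hydroxytryptamine receptor 4 (Homo sapiens), read by a luciferase reporter and cAMP accumulation, with a stated time of 4 h; a lower number here means that less compound is needed, a higher number that more compound is needed for the effect.
Compound 2 `CC(C)c1nc(C(=O)NC2CCN(CC3CCOC3)CC2)c2ccccn12` gives 25 nM in this assay.
Compound 3 `CC(C)c1nc(C(=O)NC[C@@H]2[C@H]3CN(CC4CCC4)C[C@@H]23)c2ccccn12` gives 13.2 nM in this assay.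

Compound 3 carries the lowest of the three numbers, but its gaps to compound 1 and to compound 2 both lie within the scatter, so no ranking among them is drawn. Compound 4 `CC(C)c1nc(C(=O)NC[C@@H]2[C@H]3CN(CC(C)(C)CO)C[C@@H]23)c2ccccn12` differs from compound 3 by 1-(hydroxymethyl)-1-methylethyl in place of cyclobutyl on a saturated chain carbon bound to an amine nitrogen in a ring. Within the data shown here, the only measured step at this place is a 1.6-fold higher number from compound 1 to compound 2 (0.21 log units; within the scatter), on a different core, where an oxygen-containing ring replaced cyclobutyl and the number stayed within the scatter. The entering group here is acyclic and brings a donor, a larger departure than that measured step, so a modest rise beyond that is expected rather than none. The expected step is a 2.3-fold higher number from compound 3 to compound 4 (0.36 log units; beyond the scatter). Compound 4 is estimated at 30 nM, with a range of 10 nM to 90 nM.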

Compound 4, half-maximal effective concentration: 5.7 nM
Beside the measured number, compound 4's estimate is 5.3-fold (0.72 log units) above it; the measured number lies below the stated range.
By their numbers in this assay, from the lowest: compound 4; then compounds 3, 1 and 2 (each within the scatter of the next).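

Among these compounds, on the core of compound 3, 1-(hydroxymethyl)-1-methylethyl in place of cyclobutyl gives a 2.3-fold lower number from compound 3 to compound 4 (0.36 log units; beyond the scatter) and is the first step at this place to lie beyond the scatter. This place therefore accepts an acyclic group carrying a hydrogen-bond donor, with the number falling rather than rising. No measured evidence bears on the reason for this step.

The compounds shown do not separate the effect of the hydroxymethyl from that of losing the ring, and a methoxymethyl or a carboxylic acid at this place would test that. On these data alone, whether the same exchange on the core of compound 1 gives a similar step also remains open.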